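The source may report more compounds than this note shows. Statements on the series, on what has been measured and on what is new or still open speak of the compounds shown alone.

Measured compounds:
- compound 1, `Nc1ccccc1NC(=O)/C=C/c1ccc(CSc2ccc(F)cc2)cc1`: 1190 nM
- compound 2, `Cc1cc(C)cc(SCc2ccc(C(=O)Nc3ccccc3N)cc2)c1`: 2890 nM
- compound 3, `Nc1ccccc1NC(=O)c1ccc(CSc2ccc(Cl)cc2)cc1`: "not determined" (no result reported)

Of the two numbers in hand in a functional assay on A549 cells (Homo sapiens) for antiproliferative activity, read by CCK-8 assay, with a stated time of 72 h (a lower number here means a stronger inhibitor, a higher number a weaker inhibitor), compound 1 has the lower one, and the gap from compound 1 to compound 2 lies beyond the usual scatter of the assay. Compound 3 adds nothing to the comparison, since no number was reported for it.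

The next compound, compound 4, `CCc1ccc(SCc2ccc(/C=C/C(=O)Nc3ccccc3N)cc2)cc1`, is reached from compound 1 by a single change: ethyl in place of fluoro on an aromatic carbon. Cut one bond further out, the change reads (4-fluorophenyl)sulfanyl to (4-ethylphenyl)sulfanyl, on the aromatic carbon para to a large group. For the measured compounds named here, no two measured compounds differ in one place, so no measured step is available to size this change. The expectation is for a step from compound 1 to compound 4 of a 1.3-fold higher number from compound 1 to compound 4 (0.10 log units; within the scatter), that is, a shift in this assay that does not clearly leave the scatter in either direction. Compound 4 is accordingly estimated at 1500 nM, with a range from 500 nM to 4500 nM.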

Compound 4, half-maximal inhibitory concentration: 1300 nM
Compound 4: middle estimate off by 1.2-fold (0.06 log units), on the high side, and the stated range covers the measured number.
By their numbers in this assay, from the lowest: compounds 1 and 4 (each within the scatter of the next); then compound 2.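

In this assay, for the compounds shown here, ethyl in place of fluoro on an aromatic carbon para to a large group gives a 1.1-fold higher number from compound 1 to compound 4 (0.04 log units; within the scatter) and provides the first step that isolates a single place. At this position, 4-fluorophenyl and 4-ethylphenyl cannot be told apart in this read-out, even though the entering group has 2 heavy atoms and the leaving group has 1. No measured property bears on this result, so the data offer no explanation for it.

From the compounds shown here alone, whether an amine, a carboxylic acid or a chain longer than ethyl at this position would move the number beyond the scatter remains open. Also open, going by these compounds, is whether the same exchange would read the same way on the core of compound 2.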